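Series notes: hydrogen for methoxy, compound 2 to compound 4

The source may report more compounds than this note shows. Statements on the series, on what has been measured and on what is new or still open speak of the compounds shown alone.

Measured compounds:
Compound 1 `O=C(/C(=C\c1c(-c2ccccc2)[nH]c2ccccc12)S(=O)(=O)c1ccccc1)c1ccccc1` — in a functional assay on A498 cells (Homo sapiens) for inhibition, read by sulforhodamine B assay, with a stated time of 48 h (a lower number here means a stronger inhibitor of growth, a higher number a weaker inhibitor of growth), compound 1 gives "not determined" (no result reported).
Compound 2 `COc1ccc(-c2[nH]c3ccc(OC)cc3c2/C=C(\C#N)S(=O)(=O)c2ccccc2)cc1` — in this assay compound 2 gives "not determined" (no result reported).
Compound 3 `CC(=O)/C(=C\c1c(-c2ccccc2)[nH]c2ccccc12)S(=O)(=O)c1ccccc1` — in this assay compound 3 gives 2000 nM.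

Compound 2 stands without a single number in this assay; compound 1 is the other entry without one, so compound 3 alone carries a value here. Compound 4 `COc1ccc(-c2[nH]c3ccccc3c2/C=C(\C#N)S(=O)(=O)c2ccccc2)cc1` differs from compound 2 by hydrogen in place of methoxy on an aromatic carbon. Among the measured compounds shown here, no measured pair shows this change, so its size in this assay is not known from the data; the expectation is a step no larger than the scatter, in either direction. For the measured compounds named here, the only anchor is compound 3 at 2000 nM. Compound 4 is therefore estimated at 3000 nM, with a range from 500 nM to 20000 nM.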

Compound 4, concentration for 50% growth inhibition: 1100 nM
The estimate for compound 4 lay 2.7-fold (0.44 log units) above the measured number; the range from low to high includes it.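

Among the compounds shown here, no step from compound 2 to compound 4 can be read, since compound 2 carries no single number. The compounds shown leave open what hydrogen in place of methoxy does in this assay. No evidence here bears on the result.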